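Thiosemicarbazide amidines: morpholine versus thiomorpholine on the thiocarbonyl

A few compounds are considered here, and "the series" means these few. Any claim that something is new, unique, unknown or untested is made for them only; others in the source may bear on it.

Compound 1 `Cc1cccc(/C(N)=N/NC(=S)N2CCSCC2)n1` and compound 2 `Cc1cccc(/C(N)=N/NC(=S)N2CCOCC2)n1` share a core and differ only by morpholin-4-yl in place of thiomorpholin-4-yl on a thiocarbonyl carbon. In a functional assay on A-431 cells (Homo sapiens) for cytotoxicity, read by MTT assay, with a stated time of 72 h, tested at 30 uM (on this read-out higher numbers stand for more inhibition of growth at the one concentration tested and lower numbers for less inhibition of growth), compound 1 gives 64.5%, and compound 2 gives 80%; the change makes a step of a number 15.5 percentage points higher from compound 1 to compound 2 (beyond the scatter).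

Compound 3 `N/C(=N\NC(=S)N1CCSCC1)c1ccc(F)cn1` carries a different core; the difference between its core and the core of compound 1 is not broken down here. In this assay compound 3 gives 84.6%, the highest number of the three measured, though its gap to compound 2 lies within the scatter.

Compound 4 `N/C(=N\NC(=S)N1CCOCC1)c1ccc(F)cn1` is compound 3 with morpholin-4-yl in place of thiomorpholin-4-yl on a thiocarbonyl carbon, the same change as from compound 1 to compound 2. The step from compound 3 to compound 4 is expected to be a number 6.4 percentage points higher from compound 3 to compound 4 (within the scatter), smaller than the earlier one, because compound 3 already stands at 84.6% and the read-out cannot rise much further. Compound 4 is estimated at 91%, between 80% and 99%.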

Compound 4, percent growth inhibition at one concentration: 82.3%
For compound 4 the middle estimate is 8.7 percentage points above the measured one, within the range that was stated.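

On the core of compound 3, morpholin-4-yl in place of thiomorpholin-4-yl gives a number 2.3 percentage points lower from compound 3 to compound 4 (within the scatter) in this assay and so leaves no readable effect at this one concentration. Two cores give no rule for a third, and these numbers do not show why the steps differ. The change does not carry over at the same size from the core of compound 1 to the core of compound 3: the same change on two cores in this assay, a number 15.5 percentage points higher (beyond the scatter) from compound 1 to compound 2 and a number 2.3 percentage points lower (within the scatter) from compound 3 to compound 4, 17.8 percentage points apart, beyond the scatter of two such steps

Open, as far as these compounds go, is how a piperidin-1-yl or a 4-methylpiperazin-1-yl group on the thiocarbonyl carbon would compare with morpholin-4-yl and thiomorpholin-4-yl on either core. Also open, from the compounds shown here alone, is whether the same gap between the two steps would appear on a third core.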